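The source may report more compounds than this note shows. Statements on the series, on what has been measured and on what is new or still open speak of the compounds shown alone.

Measured so far in a functional assay on PANC-1 cells (Homo sapiens) for inhibition, read by MTT assay, with a stated time of 24 h; a lower number here means a stronger inhibitor, a higher number a weaker inhibitor:
compound 1, `Cc1ccccc1-n1cc(CN2C(=O)C[C@@H]3CC[C@@]2(C)C3(C)C)nn1`: 250 nM
compound 2, `CC1(C)[C@H]2CC[C@]1(C)N(Cc1cn(-c3ccccc3)nn1)C(=O)C2`: 160 nM
compound 3, `CC1(C)[C@H]2CC[C@]1(C)N(Cc1cn(-c3ccccc3C#N)nn1)C(=O)C2`: 240 nM

Compound 3 holds the second highest of these three numbers. Its nearest neighbour is compound 1, shown by a 1.0-fold lower number from compound 1 to compound 3 (0.02 log units; within the scatter); the furthest is compound 2, shown by a 1.5-fold higher number from compound 2 to compound 3 (0.18 log units; within the scatter). Compound 4, `CC1(C)[C@H]2CC[C@]1(C)N(Cc1cn(-c3cccc(Br)c3)nn1)C(=O)C2`, differs from compound 3 by 3-bromophenyl in place of 2-cyanophenyl on an aromatic nitrogen. Among the measured compounds shown here, every measured step so far changes the group on this same phenyl ring, and all three are small: a 1.6-fold lower number from compound 1 to compound 2 (0.19 log units; within the scatter), a 1.0-fold lower number from compound 1 to compound 3 (0.02 log units; within the scatter) and a 1.5-fold higher number from compound 2 to compound 3 (0.18 log units; within the scatter). No step beyond the scatter is therefore expected in this assay. The expected step is a 1.1-fold lower number from compound 3 to compound 4 (0.04 log units; within the scatter). Compound 4 is estimated at 220 nM, within a range from 110 nM to 450 nM.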

Compound 4, half-maximal inhibitory concentration: 90 nM
For compound 4 the middle estimate is 2.4-fold (0.39 log units) above the measured one, outside the stated range (below it).
By their numbers in this assay, from the lowest: compounds 4, 2, 3 and 1 (each within the scatter of the next, the first and the last beyond it).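

In this assay, among the compounds shown here, 3-bromophenyl on the aromatic nitrogen gives the first steps beyond the scatter at this position, a 2.7-fold lower number from compound 3 to compound 4 (0.43 log units; beyond the scatter) and a 2.8-fold lower number from compound 1 to compound 4 (0.44 log units; beyond the scatter), both modest, while a 1.8-fold lower number from compound 2 to compound 4 (0.25 log units; within the scatter) stays within it. A change on this ring can therefore move the number beyond the scatter, but here only against 2-cyanophenyl and 2-methylphenyl, not against plain phenyl. Nothing available explains this result.

The compounds shown do not separate the bromo group from its place on the ring. They also leave open how an amine or a carboxylic acid on this phenyl ring would read.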